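The source may hold more compounds than are shown below. What is called first, only, known or untested is meant among the compounds shown, and "the series" means these compounds.

Compound 1 `Cc1cc(NCc2ccc(-c3ccccc3-c3nn[nH]n3)cc2)c(Cl)c(C)n1` gives 0.03 mg/kg in a functional assay on the whole organism for inhibition, with Rattus norvegicus as the target; a lower number here means that less compound is needed, a higher number that more compound is needed for the effect.
Compound 2 `CCc1cc(NCc2ccc(-c3ccccc3-c3nn[nH]n3)cc2)c(Cl)c(CC)n1` gives 0.06 mg/kg in this assay.

Among the compounds with values here, compound 2 is one of only two measured compounds, and its number and that of compound 1 lie within the usual scatter of each other, so the two cannot be told apart. Compound 3 `CCc1cc(NCc2ccc(-c3ccccc3-c3nn[nH]n3)cc2)c(Br)c(CC)n1` differs from compound 2 by bromo in place of chloro on an aromatic carbon. Within the data shown here, no measured pair shows this exchange, so there is no step to lean on. The exchange is one halogen for another at the same place. A step in this assay of no more than the scatter is expected, in either direction. For compound 3 the estimate is 0.06 mg/kg, within a range from 0.025 mg/kg to 0.15 mg/kg. That corresponds to an expected step of no change at the digits printed from compound 2 to compound 3 (within the scatter).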

Compound 3, dose for half-maximal effect: 0.09 mg/kg
Compound 3: the middle estimate sits 1.5-fold (0.18 log units) below what was measured, and the stated range covers the measured number.
By their numbers in this assay, from the lowest: compounds 1, 2 and 3 (each within the scatter of the next, the first and the last beyond it).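

Putting bromo in place of chloro on this aromatic carbon gives a 1.5-fold higher number from compound 2 to compound 3 (0.18 log units; within the scatter) in this assay, so the two halogens cannot be told apart here. With both ethyl groups kept, this position therefore takes either halogen without a change that stands clear of the scatter. Nothing at hand gives a measured reason for this result.

From the compounds shown here alone, whether fluoro, a methoxy group or an amine at this place would give a similar number stays open. So does whether the same exchange would behave alike with the methyl groups of compound 1.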